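Reversing the amide in a melatonin receptor ligand series

The source may hold more compounds than are shown below. What is called first, only, known or untested is meant among the compounds shown, and "the series" means these compounds.

Two compounds with the same shared core and a flexible side chain ending in an amide have been measured. Compound 1 `CC(=O)NCCCc1cccc2c1OCCO2` gives 126 nM in an assay (Ovis aries) for binding affinity to melatonin receptor type 1A (Homo sapiens); on this read-out lower numbers stand for stronger inhibition and higher numbers for weaker inhibition. Compound 2 `CC(=O)NCCCCc1cccc2c1OCCO2`, whose chain is one carbon longer, gives 158 nM in this assay. Compound 2 thus holds the highest of the two numbers, but the step of a 1.3-fold higher number from compound 1 to compound 2 (0.10 log units; within the scatter) lies within the scatter, so the two values cannot be told apart.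

Compound 3 `CNC(=O)CCCCc1cccc2c1OCCO2` keeps every atom of compound 2 and joins them differently: methylcarbamoyl in place of acetamido on a saturated chain carbon, four bonds along the chain from an aromatic carbon. Among the measured compounds shown here, the one measured step concerns chain length, not the direction of the amide, so it offers only a loose guide; it shows that a small change at the chain end left the number essentially unmoved. For the measured compounds named here, no measured compound tests the reversed amide itself, and the expectation therefore carries a wide range. Compound 3 is expected to give a modestly higher number, a step of a 2.5-fold higher number from compound 2 to compound 3 (0.40 log units; beyond the scatter), with the estimate for compound 3 at 400 nM, ranging from 100 nM to 2000 nM.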

Compound 3, half-maximal inhibitory concentration: 50.1 nM
Estimate against measurement, compound 3: 8.0-fold (0.90 log units) above; the whole stated range lies above it.
By their numbers in this assay, from the lowest: compound 3; then compounds 1 and 2 (each within the scatter of the next).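

The direction of the amide matters at this place on the chain: with the atoms, the hydrogen-bond donor and the hydrogen-bond acceptor count unchanged, methylcarbamoyl in place of acetamido gives a 3.2-fold lower number from compound 2 to compound 3 (0.50 log units; beyond the scatter) in this assay and so moves the number beyond the scatter, which the change in chain length among the acetamido compounds did not do. Compound 3 also stands apart from the shorter acetamido compound, with a 2.5-fold lower number from compound 1 to compound 3 (0.40 log units; beyond the scatter) in the same read-out, so it is the most potent of the three compounds here, though only modestly so. No supporting measurement is available to explain why this way of joining the amide gives the lower number.

The compounds shown leave open whether methylcarbamoyl keeps this advantage on a shorter or longer chain, since the reversed amide appears here on one chain length only. They also leave open how far the end of the chain tolerates change, for instance whether ethylcarbamoyl, an unsubstituted carboxamide or a carboxylic acid in place of methylcarbamoyl would hold, lower or raise the number.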